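The compounds below may be only part of what the source reports. "The series", "measured", "known", "first", "only" and "open" are said of these compounds alone.

Compound 1 `CC(=O)N1CCC(C(=O)N2N=CCC2c2ccccc2)CC1` is a small amide built around a shared core, and in a physicochemical assay for lipophilicity, read by HPLC, measured as chromatographic lipophilicity, at pH 7.4 (a lower number here means a more polar compound, a higher number a more lipophilic compound), compound 1 gives 2.5. Its closest measured relative is compound 2 `CC(=O)N1CCC(C(=O)N2N=CC[C@H]2c2ccccc2)CC1`, which in this assay gives 2.5. Among the compounds with values here, the single recorded step between them, no change at the digits printed from compound 1 to compound 2 (within the scatter), shows no movement beyond the scatter, which fits with the fact that one of compounds 1 and 2 is drawn with a defined configuration and the other without, at the place where they differ: the two compounds share every atom and bond and differ only in how one stereocentre is drawn.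

Compound 3 `O=C(c1ccccn1)N1CCC(C(=O)N2N=CCC2c2ccccc2)CC1` has not yet been measured. It differs from compound 1 by pyridin-2-yl in place of methyl on a carbonyl carbon. Within the data shown here, none of the measured steps touches this part of the molecule, so nothing measured here directly bears on the change from acetyl to (pyridin-2-yl)carbonyl; the estimate below rests on the structural change alone. Compound 3 is expected to show a modest upward step, a number 0.40 log units higher from compound 1 to compound 3 (beyond the scatter), in this assay. Compound 3 is therefore estimated at 2.9, with a range from 2.3 to 3.5.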

Compound 3, distribution coefficient: 3.1
Compound 3: middle estimate off by 0.20 log units, on the low side; the measured number falls inside the stated range.
By their numbers in this assay, from the lowest: compounds 1 and 2 (each within the scatter of the next); then compound 3.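

Within the data shown here, the change on the carbonyl carbon is the first step here to move the reading in this assay: pyridin-2-yl in place of methyl gives a number 0.60 log units higher from compound 1 to compound 3 (beyond the scatter). This place on the molecule can therefore shift the number beyond the scatter, which the difference in how one stereocentre is drawn did not do, although a single pair of compounds sets no trend. Nothing at hand indicates which feature of the incoming group accounts for this step.

With only methyl and pyridin-2-yl at this place, the contribution of the ring cannot be separated from that of its nitrogen, and a plain phenyl group would be the direct comparison. Going by these compounds, how an amine or a carboxylic acid carried on the same carbonyl carbon would read also remains open.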